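This account rests on a few compounds, and the source may have more. Where it says the series, first, only, none or still open, it means among the compounds named here.

Measured compounds in an assay on CHO cells for agonist activity at Neuronal acetylcholine receptor; alpha3/alpha6/beta2/beta3 (Homo sapiens), read by FLIPR and calcium flux; on this read-out lower numbers stand for an effect already at smaller amounts and higher numbers for an effect only at larger amounts of compound:
compound 1 `CCC(=O)N1CC2CC(C1)N2` gives 180 nM
compound 2 `O=C(C1CCC1)N1CC2CC(C1)N2` gives 370 nM
compound 3 `O=C(C1CC=CC1)N1CC2CC(C1)N2` gives 1900 nM

Compound 2 stands second highest of the three in this assay; compound 1 sits nearest, compound 3 furthest. The measured step bearing on the change is a 2.1-fold higher number from compound 1 to compound 2 (0.31 log units; beyond the scatter), where a larger ring on the carbonyl carbon gave the higher number. For the measured compounds named here, compound 3, with a still larger ring, shows the highest number, though no single step to it is computed.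

Compound 4 `O=C([C@H]1C[C@@H]1F)N1CC2CC(C1)N2` carries 2-fluorocyclopropyl in place of cyclobutyl on a carbonyl carbon. Going by the values given here, the entering ring is smaller than the one it replaces and adds fluorine, for which no measured step exists. Going by compound 1 and its step to compound 2, a modestly lower number in this assay is expected; the estimate for compound 4 is 250 nM, range 100 nM to 700 nM, a step of a 1.5-fold lower number from compound 2 to compound 4 (0.17 log units; within the scatter).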

Compound 4, half-maximal effective concentration: 620 nM
Estimate against measurement, compound 4: 2.5-fold (0.39 log units) below; the measured number falls inside the stated range.
By their numbers in this assay, from the lowest: compound 1; then compounds 2 and 4 (each within the scatter of the next); then compound 3.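

In this assay, 2-fluorocyclopropyl in place of cyclobutyl on a carbonyl carbon gives a 1.7-fold higher number from compound 2 to compound 4 (0.22 log units; within the scatter), so this assay does not separate these two small rings. Set against the ethyl group, the same ring gives a 3.4-fold higher number from compound 1 to compound 4 (0.54 log units; beyond the scatter), so the smaller ring does not return the number to that of compound 1. No measurement on hand accounts for these numbers.

The compounds shown leave open what the fluorine contributes, which plain cyclopropyl on the same carbonyl carbon would address. They also leave open whether the mirror-image 2-fluorocyclopropyl would read the same.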